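A few compounds are considered here, and "the series" means these few. Any claim that something is new, unique, unknown or untested is made for them only; others in the source may bear on it.

Compound 1 `COc1ccc(Nc2nc3ccccc3nc2S(=O)(=O)c2ccc(C)cc2)cc1` was tested in a functional assay on PC-3 cells (Homo sapiens) for cytotoxicity, read by MTT assay, with a stated time of 72 h; a higher number here means a weaker inhibitor, a lower number a stronger inhibitor. For compound 1 the result is a limit, > 50000 nM. Compound 2 `Cc1ccc(S(=O)(=O)c2nc3ccccc3nc2Nc2ccc(N)cc2)cc1` gives 5000 nM. Compound 3 `Cc1ccc(S(=O)(=O)c2nc3ccccc3nc2Nc2cccc(O)c2)cc1` gives 1690 nM, the lowest of the two numbers shown, with compound 2 nearest.

The three measured compounds share a core and differ only in the group on the nitrogen. The steps show an at least 10-fold lower number from compound 1 to compound 2 (1.00 log units; beyond the scatter), an at least 29-fold lower number from compound 1 to compound 3 (1.47 log units; beyond the scatter) and a 3.0-fold lower number from compound 2 to compound 3 (0.47 log units; beyond the scatter). One of the three values sits at the limit of > 50000 nM in this assay, at which 1 of the 3 values shown sits, so the first two of these steps are known only as lower bounds.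

Compound 4 `Cc1ccc(S(=O)(=O)c2nc3ccccc3nc2Nc2ccc(C(F)(F)F)cc2)cc1` is not yet measured. Its difference from compound 3 is 4-(trifluoromethyl)phenyl in place of 3-hydroxyphenyl on a nitrogen on an aromatic ring. Among the measured compounds shown here, the steps that bear on this change are those ending at compound 3, an at least 29-fold lower number from compound 1 to compound 3 (1.47 log units; beyond the scatter) and a 3.0-fold lower number from compound 2 to compound 3 (0.47 log units; beyond the scatter), both of which gave lower numbers when 3-hydroxyphenyl replaced a 4-substituted phenyl. Reversing that direction, a higher number is expected for compound 4, beyond the scatter. Compound 4 is therefore estimated at 8000 nM, in the range 2500 nM to 30000 nM, which is expected to mean a 4.7-fold higher number from compound 3 to compound 4 (0.68 log units; beyond the scatter).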

Compound 4, half-maximal inhibitory concentration: 2540 nM
Estimate against measurement, compound 4: 3.1-fold (0.50 log units) above; measured number inside the range.
By their numbers in this assay, from the lowest: compounds 3, 4 and 2 (each within the scatter of the next, the first and the last beyond it). At a limit, above all of these: compound 1.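

Trifluoromethyl in place of amino on an aromatic carbon gives a 2.0-fold lower number from compound 2 to compound 4 (0.29 log units; within the scatter), and 4-(trifluoromethyl)phenyl in place of 3-hydroxyphenyl on this nitrogen gives a 1.5-fold higher number from compound 3 to compound 4 (0.18 log units; within the scatter). Among the compounds shown here, the earlier compounds set the 3-hydroxyphenyl apart from both 4-substituted phenyls, but compound 4 shows that a 4-substituted phenyl with 0 hydrogen-bond donors and 0 hydrogen-bond acceptors can lie within the scatter of it, leaving the 4-methoxyphenyl of compound 1 as the one group that goes against this. Trifluoromethyl in place of methoxy gives an at least 19-fold lower number from compound 1 to compound 4 (1.29 log units; beyond the scatter), which is only a lower bound, as the value of compound 1 is a limit: the limit of > 50000 nM in this assay, at which 1 of the 4 values shown sits.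

The compounds shown leave open why methoxy alone stands apart at this place. They also leave open how a carboxylic acid or a longer chain in place of the trifluoromethyl would compare.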